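Chain-terminus variation in the CXCR4 antagonist series

The compounds below may be only part of what the source reports. "The series", "measured", "known", "first", "only" and "open" are said of these compounds alone.

Compound 1 `c1cncc(CNCCCCN(C[C@H]2Cc3ccccc3CN2)[C@H]2CCCc3cccnc32)c1` is the reference point. In a functional assay on cells for antagonist activity at C-X-C chemokine receptor type 4 (Homo sapiens), read by fluorescence and calcium flux, with stated times of 25 min and 90 s (a higher number here means a weaker inhibitor, a lower number a stronger inhibitor), compound 1 gives 15.3 nM, the lowest of the three numbers recorded so far. Compound 2 `c1ccc2c(c1)CN[C@@H](CN(CCCCNC1CCSCC1)[C@H]1CCCc3cccnc31)C2` gives 54.7 nM, and compound 3 `O=S1(=O)CCC(NCCCCN(C[C@H]2Cc3ccccc3CN2)[C@H]2CCCc3cccnc32)CC1` gives 45.5 nM. Both steps away from compound 1 go in the same direction: a 3.6-fold higher number from compound 1 to compound 2 (0.55 log units; beyond the scatter), and a 3.0-fold higher number from compound 1 to compound 3 (0.47 log units; beyond the scatter). Between the two saturated ring replacements the difference is negligible, a 1.2-fold lower number from compound 2 to compound 3 (0.08 log units; within the scatter).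

Compound 4 `CC(C)(N)CCCN(C[C@H]1Cc2ccccc2CN1)[C@H]1CCCc2cccnc21` differs from compound 1 as follows: 1-amino-1-methylethyl in place of (((pyridin-3-yl)methyl)amino)methyl on a saturated chain carbon, three bonds along the chain from an amine nitrogen. This removes the terminal aromatic ring entirely rather than exchanging it for another ring, and it also shortens the chain and moves the donor nitrogen onto a branched carbon.

The two steps that bear on it are those from compound 1 to compound 2 and to compound 3, each a modest loss on swapping out the (pyridin-3-yl)methyl group. Since the change to compound 4 is more drastic than either, a loss of at least the same size is expected, with a wider spread of uncertainty in this assay. For compound 4 the expected step is a 4.6-fold higher number from compound 1 to compound 4 (0.66 log units; beyond the scatter). The estimate for compound 4 in this assay is 70 nM, with a range from 20 nM to 250 nM.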

Compound 4, half-maximal inhibitory concentration: 24.6 nM
Compound 4: middle estimate off by 2.8-fold (0.45 log units), on the high side, and the stated range covers the measured number.
By their numbers in this assay, from the lowest: compounds 1, 4, 3 and 2 (each within the scatter of the next, the first and the last beyond it).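

In this assay, the terminal aromatic ring is not required at this position: replacing (((pyridin-3-yl)methyl)amino)methyl with the ring-free 1-amino-1-methylethyl group gives a 1.6-fold higher number from compound 1 to compound 4 (0.21 log units; within the scatter). Within the data shown here, the same group also stays level with the 1,1-dioxothian-4-yl terminus, at a 1.8-fold lower number from compound 3 to compound 4 (0.27 log units; within the scatter), while against the thian-4-yl terminus the result is a 2.2-fold lower number from compound 2 to compound 4 (0.35 log units; beyond the scatter), the only new step beyond the scatter. The modest losses seen with compound 2 and compound 3 therefore do not follow simply from the absence of the pyridine ring, since compound 4 has no terminal ring at all and its group has 4 heavy atoms rather than 9.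

No measurement among these compounds accounts for how this small branched terminus holds up. From the compounds shown here alone, compound 4 changes the terminal ring, the chain length and the branching at the carbon carrying the nitrogen in a single step, so their separate contributions remain open; an unbranched chain ending in a primary amine, or a chain ending in a carboxylic acid, would help separate them.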